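Aryl cinnamate esters: whole-animal read-out at one dose

The source may report more compounds than this note shows. Statements on the series, on what has been measured and on what is new or still open speak of the compounds shown alone.

Measured so far:
compound 1 `COc1ccccc1/C=C/C(=O)OC/C=C/c1cc(OC)c(OC)cc1OC`: 100%
compound 2 `COc1cc(OC)c(OC)cc1/C=C/COC(=O)/C=C/c1c(OC)ccc(OC)c1OC`: 100%
compound 3 `COc1cc(OC)c(OC)cc1/C=C/COC(=O)/C=C/c1ccccc1C(F)(F)F`: 100%

All three values above come from a functional assay on the whole organism (strain Kunming) with Mus musculus as the target, with a stated time of 0.5 h, at a dose of 100 mg/kg by the intraperitoneal route; on this read-out lower numbers stand for a stronger effect and higher numbers for a weaker effect at the one dose given. In this assay compound 3 stands level with compound 1 and compound 2 at the digits printed; its nearest neighbour is compound 1 and its furthest compound 2, both without change beyond the scatter. Among the compounds with values here, the one step measured, no change at the digits printed from compound 1 to compound 3 (within the scatter), replaces one aromatic substituent by another and moves nothing.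

Compound 4 `COc1cc(OC)c(OC)cc1/C=C/COC(=O)/C=C/c1ccc(F)cc1` is not yet measured. It differs from compound 3 as follows: 4-fluorophenyl in place of 2-(trifluoromethyl)phenyl on a double-bonded chain carbon bound to a double-bonded chain carbon. Within the data shown here, only the step from compound 1 to compound 3 bears on this change, and that step was flat; no measured step touches the place where compound 4 differs from compound 3, nor a substituent of the kind that enters. Three compounds with varied aromatic substitution all read the same, so no step beyond the scatter is expected in this assay. The expected step is no change at the digits printed from compound 3 to compound 4 (within the scatter). Compound 4 is therefore expected to give 100%, between 85% and 100%.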

Compound 4, a percentage reported as activity, at one dose (the size of the read-out at that dose, not a potency): 100%
Estimate against measurement, compound 4: no gap at the digits printed; low and high end bracket the measured number.
By their numbers in this assay, from the lowest: compounds 1, 2, 3 and 4 (each within the scatter of the next).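

Notes on the series: in this assay the place on a double-bonded chain carbon bound to a double-bonded chain carbon now has a direct reading, with 4-fluorophenyl in place of 2-(trifluoromethyl)phenyl giving no change at the digits printed from compound 3 to compound 4 (within the scatter) at the shared core. A second change at that place, 4-fluorophenyl in place of 2-methoxyphenyl, gives no change at the digits printed from compound 1 to compound 4 (within the scatter) and thus extends the flat reading to a fluorine-bearing phenyl group as well. No supporting data bear on this result.

All four compounds read alike at the one dose, so nothing yet shows that this place can shift the read-out at all. As far as these compounds go, whether an amine, a carboxylic acid or a longer chain at this place would separate from these compounds stays open.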